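Aryl Swap on a Fused Core: Expectation for Compound 4

The source may hold more compounds than are shown below. What is called first, only, known or untested is meant among the compounds shown, and "the series" means these compounds.

Compound 1, `CNC(=O)c1cc(Oc2ccc(NC(=O)c3cc4cccnc4n(-c4ccc(Br)cc4F)c3=O)cc2)ccn1`: 1420 nM
Compound 2, `CNC(=O)c1cc(Oc2ccc(NC(=O)c3cc4cccnc4n(-c4ccc(C(F)(F)F)cc4Cl)c3=O)cc2)ccn1`: 2090 nM
Compound 3, `CCNC(=O)c1cc(Oc2ccc(NC(=O)c3cc4cccnc4n(-c4ccc(Br)cc4F)c3=O)cc2)ccn1`: 1820 nM

These three numbers come from a functional assay on A549 cells (Homo sapiens) for antiproliferative activity, read by MTT assay, with a stated time of 72 h; a higher number here means a weaker inhibitor, a lower number a stronger inhibitor. Compound 4, `CCNC(=O)c1cc(Oc2ccc(NC(=O)c3cc4cccnc4n(-c4ccc(C(F)(F)F)cc4Cl)c3=O)cc2)ccn1`, has not yet been tested there. Compound 3 differs from compound 1 by methyl in place of hydrogen on a saturated chain carbon bound to an amide-type nitrogen, and the step was a 1.3-fold higher number from compound 1 to compound 3 (0.11 log units; within the scatter). Compound 4 stands to compound 3 as compound 2 stands to compound 1: the change is 2-chloro-4-(trifluoromethyl)phenyl in place of 4-bromo-2-fluorophenyl on an aromatic nitrogen, the same change as 2-chloro-4-(trifluoromethyl)phenyl in place of 4-bromo-2-fluorophenyl on an aromatic nitrogen at the same place, occurring twice among these compounds. Its measured instance gave a 1.5-fold higher number from compound 1 to compound 2 (0.17 log units; within the scatter). Compound 4 is expected to show a step of a 1.5-fold higher number from compound 3 to compound 4 (0.17 log units; within the scatter) because a 1.5-fold higher number from compound 1 to compound 2 (0.17 log units; within the scatter) is the only measured size of this change. Compound 4 is therefore estimated at 2700 nM, with a range from 1300 nM to 5500 nM.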

Compound 4, half-maximal inhibitory concentration: 3290 nM
For compound 4 the middle estimate is 1.2-fold (0.09 log units) below the measured one; the range from low to high includes it.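

In this assay the aryl exchange gave a 1.8-fold higher number from compound 3 to compound 4 (0.26 log units; within the scatter), and it read alike on both cores: the same change on two cores in this assay, a 1.5-fold higher number (0.17 log units; within the scatter) from compound 1 to compound 2 and a 1.8-fold higher number (0.26 log units; within the scatter) from compound 3 to compound 4, 1.2-fold (0.09 log units) apart, within the scatter of two such steps. The methyl in place of hydrogen on the saturated chain carbon gave a 1.6-fold higher number from compound 2 to compound 4 (0.20 log units; within the scatter), and it also matched its earlier step: the same change on two cores in this assay, a 1.3-fold higher number (0.11 log units; within the scatter) from compound 1 to compound 3 and a 1.6-fold higher number (0.20 log units; within the scatter) from compound 2 to compound 4, 1.2-fold (0.09 log units) apart, within the scatter of two such steps. Both changes therefore carried from one core to the other without a detectable difference, but every step lies within the scatter, so these four compounds show no clear effect of either change, and two cores cannot show that the agreement extends further in the series.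

On these data alone, it remains open whether a propyl chain in place of the ethyl of compound 3, or a nitrile in place of the trifluoromethyl of compound 2, would move the number beyond the scatter.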